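From 2-methoxybenzyl to 3-methoxybenzyl on a shared core

A few compounds are considered here, and "the series" means these few. Any claim that something is new, unique, unknown or untested is made for them only; others in the source may bear on it.

In a functional assay on HL-60 cells (Homo sapiens) for antiproliferative activity, with a stated time of 72 h (on this read-out higher numbers stand for weaker inhibition and lower numbers for stronger inhibition), compound 1 (`OC[C@H]1O[C@@H](n2cnc3c(NCc4ccc(Cl)cc4)ncnc32)[C@H](O)[C@@H]1O`) gives 1700 nM, and compound 2 (`OC[C@H]1O[C@@H](n2cnc3c(NCc4ccc(Br)cc4)ncnc32)[C@H](O)[C@@H]1O`) gives 47400 nM. Compound 3 (`COc1ccccc1CNc1ncnc2c1ncn2[C@@H]1O[C@H](CO)[C@@H](O)[C@H]1O`) gives 2300 nM. Two steps fix its standing: a 1.4-fold higher number from compound 1 to compound 3 (0.13 log units; within the scatter) stays within the scatter, whereas a 21-fold lower number from compound 2 to compound 3 (1.31 log units; beyond the scatter) is large, so it sits level with the first compound and far from the second.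

Compound 4 (`COc1cccc(CNc2ncnc3c2ncn3[C@@H]2O[C@H](CO)[C@@H](O)[C@H]2O)c1`) has the same atoms as compound 3, joined differently: 3-methoxyphenyl in place of 2-methoxyphenyl on a saturated chain carbon bound to a nitrogen on an aromatic ring. In words, 3-methoxyphenyl stands in place of 2-methoxyphenyl on a saturated chain carbon bound to a nitrogen on an aromatic ring. Within the data shown here, no measured step shows this exact kind of change, so the evidence is only indirect. The swap of bromo in place of chloro, a 28-fold higher number from compound 1 to compound 2 (1.45 log units; beyond the scatter), warns that one small change on the aromatic ring can be large in this assay. The replacement of 4-chlorophenyl by 2-methoxyphenyl, a 1.4-fold higher number from compound 1 to compound 3 (0.13 log units; within the scatter), shows that a methoxy-bearing ring can stay within the scatter. No direction is therefore favoured, and the expected change is none beyond the scatter, with an expected step of a 1.3-fold higher number from compound 3 to compound 4 (0.12 log units; within the scatter). Compound 4 is estimated at 3000 nM, with an expected range from 800 nM to 15000 nM.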

Compound 4, half-maximal inhibitory concentration: 4900 nM
Beside the measured number, compound 4's estimate is 1.6-fold (0.21 log units) below it; low and high end bracket the measured number.
By their numbers in this assay, from the lowest: compounds 1 and 3 (each within the scatter of the next); then compound 4; then compound 2.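

In this assay, the change from 2-methoxybenzyl to 3-methoxybenzyl leaves the atoms as they were yet gives a 2.1-fold higher number from compound 3 to compound 4 (0.33 log units; beyond the scatter), so where the methoxy group sits on the ring can alone move the number beyond the scatter at this place, though only modestly. Set against the 4-chlorophenyl group, the 3-methoxyphenyl group gives a 2.9-fold higher number from compound 1 to compound 4 (0.46 log units; beyond the scatter), a gap beyond the scatter where the 2-methoxyphenyl group stayed within it, while against the 4-bromophenyl group it gives a 9.7-fold lower number from compound 2 to compound 4 (0.99 log units; beyond the scatter). A methoxy-bearing ring at this place therefore does not guarantee a number level with that of compound 1, although neither methoxy compound comes close to the high number of compound 2.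

No measurement shown accounts for the step between the two methoxy compounds, so its cause stays unknown. The compounds shown also leave open whether a hydroxyl or an amine on the ring, in place of the methoxy group, would keep the number in this range.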